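Extending a Methyl to a Propyl on the Anilide

The source may hold more compounds than are shown below. What is called first, only, known or untested is meant among the compounds shown, and "the series" means these compounds.

Compound 1 `COc1ccc2nc(C)cc(OCC(=O)Nc3ccc(C)cc3)c2c1` and compound 2 `COc1ccc2nc(C)cc(OCC(=O)Nc3ccc4c(c3)CCCC4)c2c1` share one core and differ only in the group carried by the amide nitrogen. Among the measured compounds shown here, in an ADME assay on liver (Homo sapiens) for metabolic stability, read by LC-MS, using S9 fraction, tested at 2 uM (on this read-out lower numbers stand for a shorter-lived compound and higher numbers for a longer-lived compound), compound 1 gives 0.423 h, the higher of the two numbers measured so far. In this assay compound 2 gives 0.27 h, and these two values lie within the usual scatter of each other, so no order between them can be claimed.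

Compound 3 `CCCc1ccc(NC(=O)COc2cc(C)nc3ccc(OC)cc23)cc1` has not yet been measured. Relative to compound 1 the change is ethyl in place of hydrogen on a saturated chain carbon bound to an aromatic carbon. For the measured compounds named here, with only two measured compounds and no step between them beyond the scatter, nothing anchors a firm direction for this change. The expected step in this assay is a 1.4-fold lower number from compound 1 to compound 3 (0.15 log units; within the scatter), leaning toward a somewhat shorter-lived compound but not clearly beyond the scatter. Compound 3 is therefore expected to give 0.3 h in this assay, with a plausible range from 0.12 h to 0.7 h.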

Compound 3, half-life: 0.503 h
Beside the measured number, compound 3's estimate is 1.7-fold (0.22 log units) below it, and the stated range covers the measured number.
By their numbers in this assay, from the lowest: compounds 2, 1 and 3 (each within the scatter of the next).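

Exchanging 4-methylphenyl for 4-propylphenyl, that is, ethyl in place of hydrogen on a saturated chain carbon bound to an aromatic carbon, gives a 1.2-fold higher number from compound 1 to compound 3 (0.08 log units; within the scatter) in this assay and so leaves compound 1 and compound 3 indistinguishable on this read-out. Among the compounds shown here, this is the first direct reading at this position: two extra carbons on the chain can be added without a half-life difference that stands clear of ordinary repeat-to-repeat variation. Nothing available explains this result or links it to any property of the chain.

As far as these compounds go, whether a longer chain such as hexyl, an amine or a carboxylic acid in place of the propyl would give a half-life clearly apart from that of compound 1 remains open. So does whether this single step would read the same on a different core.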